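Replacing the methylcarbamoyl of compound 2 with amino

This account rests on a few compounds, and the source may have more. Where it says the series, first, only, none or still open, it means among the compounds named here.

For the measured compounds named here, compound 2 `CNC(=O)c1cccc(CNc2cc(C(F)(F)F)cc3[nH]ncc23)c1` gives the higher of the two numbers measured so far in an assay for inhibition of Tryptophan 2,3-dioxygenase (Homo sapiens), with stated times of 10 min and 60 min, tested at 100 uM (on this read-out lower numbers stand for a weaker effect and higher numbers for a stronger effect at the one concentration tested), namely 91%. Going by the values given here, its nearest measured neighbour is compound 1 `OC1CCCC(Nc2cccc(CNc3cc(C(F)(F)F)cc4[nH]ncc34)c2)C1`, which in this assay gives 23%; the step of a number 68 percentage points higher from compound 1 to compound 2 (beyond the scatter) is the only one recorded for an exchange at this aromatic carbon. Compound 3 `Nc1cccc(CNc2cc(C(F)(F)F)cc3[nH]ncc23)c1` differs from compound 2 at the same place: amino in place of methylcarbamoyl on an aromatic carbon. The amino group sits on an aromatic carbon of a six-membered aromatic ring of carbon only, meta to a large group. Among the compounds with values here, no measured step covers this exact exchange; the one step available shows only that the group at this carbon can move the read-out strongly, with the methylcarbamoyl carrying the higher number and a different amino-type group the lower one. Compound 3 is therefore expected to fall below compound 2 by a number 36 percentage points lower from compound 2 to compound 3 (beyond the scatter), with wide uncertainty. Compound 3 is estimated at 55% in this assay, in a range from 20% to 90%.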

Compound 3, a percentage reported as inhibition, at one concentration (the size of the read-out at that concentration, not a potency): 89%
Compound 3: the middle estimate sits 34 percentage points below what was measured; the measured number falls inside the stated range.
By their numbers in this assay, from the lowest: compound 1; then compounds 3 and 2 (each within the scatter of the next).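

In this assay the exchange of methylcarbamoyl for amino on this aromatic carbon gives a number 2 percentage points lower from compound 2 to compound 3 (within the scatter) so the carbonyl and the methyl of the methylcarbamoyl, 4 heavy atoms against 1, are not needed for a high number at the one concentration tested. On the nitrogen on an aromatic ring, hydrogen in place of 3-hydroxycyclohexyl gives a number 66 percentage points higher from compound 1 to compound 3 (beyond the scatter) so the low number of compound 1 goes with the 3-hydroxycyclohexyl and not with a nitrogen on this carbon as such. No measured evidence at hand bears on the cause of either step.

On these data alone, a read-out at one concentration gives no potency, and whether compound 2 and compound 3 would part at a lower concentration stays open. Also open, as far as these compounds go, is how a methyl or a longer chain on that nitrogen compares with hydrogen and with 3-hydroxycyclohexyl, and whether a hydroxyl or a carboxylic acid on this aromatic carbon keeps the number that amino and methylcarbamoyl give.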